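The compounds below may be only part of what the source reports. "The series", "measured", "known", "first", "only" and "open" are said of these compounds alone.

The shared core is the same in all four compounds; they differ in the groups hung on it. Compound 1 `O=C1Nc2ccc(Cl)cc2/C1=N/NC(=S)N1CCN(c2ccccc2F)CC1` carries a chloro on the core and a larger substituent on the far side; in a functional assay on A549 cells (Homo sapiens) for inhibition, read by MTT assay, with a stated time of 72 h (a lower number here means a stronger inhibitor, a higher number a weaker inhibitor), compound 1 gives 10500 nM. Compound 2 `O=C1Nc2ccc(Cl)cc2/C1=N/NC(=S)N1CCN(c2ccccc2[N+](=O)[O-])CC1` has nitro in place of fluoro, and in this assay compound 2 gives 5580 nM. Within the data shown here, the only measured step, a 1.9-fold lower number from compound 1 to compound 2 (0.27 log units; within the scatter), concerns that nitro-for-fluoro swap. Compound 3 `O=C1Nc2ccccc2/C1=N/NC(=S)Nc1ccccc1` lacks the chloro and bears a plain phenyl on the far side. In this assay compound 3 gives only a limit, > 100000 nM, not a number. It sits at the limit of > 100000 nM in this assay, at which 1 of the 3 values shown sits. Compound 4 `O=C1Nc2ccc(Cl)cc2/C1=N/NC(=S)Nc1ccccc1` differs from compound 3 by chloro in place of hydrogen on an aromatic carbon. Among the measured compounds shown here, no measured step covers a chloro-for-hydrogen change, so the step from compound 1 to compound 2 gives no direct guide; compounds 1 and 2 do carry the chloro and give numbers rather than limits, but they differ from compound 4 elsewhere too. Compound 4 is expected to stay weak, the estimated step being an at least 1.6-fold lower number from compound 3 to compound 4 (0.22 log units; that floor lies within the scatter). The estimate for compound 4 in this assay is 60000 nM, between 15000 nM and 200000 nM.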

Compound 4, half-maximal inhibitory concentration: 33100 nM
The estimate for compound 4 lay 1.8-fold (0.26 log units) above the measured number; the range from low to high includes it.
By their numbers in this assay, from the lowest: compounds 2 and 1 (each within the scatter of the next); then compound 4. At a limit, above all of these: compound 3.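

Before this result, the only measured step was on the far side of the molecule, so nothing showed whether the core itself could change the number. In this assay, chloro in place of hydrogen on an aromatic carbon of the shared core gives an at least 3.0-fold lower number from compound 3 to compound 4 (0.48 log units; beyond the scatter), with the plain phenyl on the far side unchanged. This single swap therefore moves the result by more than the scatter, and the true step may be larger, because compound 3 gives a limit and not a number: the limit of > 100000 nM in this assay, at which 1 of the 4 values shown sits.

Going by these compounds, whether another group on this carbon, such as bromo, methoxy or an amine, would give a lower or higher number remains open. Also open is whether chloro gives a similar step when the far side carries the larger substituent of compound 1, as no partner without the chloro is shown for that compound.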